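The compounds below may be only part of what the source reports. "The series", "measured", "known", "first", "only" and "open" are said of these compounds alone.

Measured compounds in the series:
- compound 1, `O=C(NO)c1ccc(NCc2nc(-c3cccc(Cl)c3)nn2-c2ccccc2)cc1`: 61.2%
- compound 2, `NC(=O)c1ccc(NCc2nc(-c3ccccc3)nn2-c2ccccc2)cc1`: -4.4%
- compound 3, `O=C(NO)c1ccc(NCc2nc(-c3cccs3)nn2-c2ccc(O)cc2)cc1`: 79.6%

In an assay on Sf9 cells for inhibition of protein deacetylase HDAC6 (Homo sapiens), read by fluorescence, with a stated time of 40 min, tested at 100 nM (on this read-out lower numbers stand for less inhibition and higher numbers for more inhibition at the one concentration tested (going by the name of the read-out)), compound 1 gives 61.2%, the second highest of the three numbers. Its nearest neighbour on the read-out is compound 3, whose value of 79.6% stands higher by a gap beyond the scatter. Furthest away is compound 2, whose value of -4.4% shows essentially no inhibition at the test concentration; the gap to compound 1 lies well beyond the scatter. No pair of these compounds differs in only one place, so no single step is yet fixed.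

The next compound, compound 4, `O=C(NO)c1ccc(NCc2nc(-c3ccncc3)nn2-c2ccccc2)cc1`, is to be measured in this assay. It differs from compound 1 in one place: pyridin-4-yl in place of 3-chlorophenyl on an aromatic carbon. The hydroxamic acid and the rest of the shared core of compound 1 are kept.

Going by the values given here, with no comparable step in hand, the expectation is a step from compound 1 to compound 4 of a number 6.2 percentage points lower from compound 1 to compound 4 (within the scatter), that is, none beyond the scatter. Compound 4 is therefore estimated at 55%, within a range from 30% to 80%.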

Compound 4, a percentage reported as inhibition, at one concentration (the size of the read-out at that concentration, not a potency): 30.8%
For compound 4 the middle estimate is 24.2 percentage points above the measured one; the measured number falls inside the stated range.
By their numbers in this assay, from the lowest: compound 2; then compound 4; then compound 1; then compound 3.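

In this assay, going by these compounds alone, pyridin-4-yl in place of 3-chlorophenyl gives a number 30.4 percentage points lower from compound 1 to compound 4 (beyond the scatter) and is the first single-place step fixed. With the hydroxamic acid and the rest of the shared core kept, the read-out therefore depends on the group carried by this aromatic carbon of the five-membered ring, although compound 4 still gives 30.8% at the one concentration tested. Nothing at hand accounts for the size of the step.

The step removes the chlorine and brings in a ring nitrogen at once, so the share of each in the change cannot be separated, and an unsubstituted phenyl on the same hydroxamic acid core would be needed to divide it. Going by these compounds, how pyridin-3-yl or a saturated ring such as cyclohexyl would read at this carbon remains open.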